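A few compounds are considered here, and "the series" means these few. Any claim that something is new, unique, unknown or untested is made for them only; others in the source may bear on it.

Compounds measured so far in an assay on isolated protein for inhibition of Amine oxidase [flavin-containing] B (Homo sapiens), read by fluorescence and Amplex Red, with stated times of 15 min and 20 min; a lower number here means a stronger inhibitor, a higher number a weaker inhibitor:

compound 1 `Oc1ccc(O)c(/C=N/c2ccc(OCc3ccccc3)cc2)c1`: 1230 nM
compound 2 `Oc1cccc(/C=N/c2ccc(OCc3ccccc3)cc2)c1O`: 6870 nM
compound 3 `O=[N+]([O-])c1ccc(O)c(/C=N/c2ccc(OCc3ccccc3)cc2)c1`: 60900 nM

Compound 3 gives the highest number of the three in this assay; its nearest neighbour is compound 2, a 5.6-fold higher number from compound 1 to compound 2 (0.75 log units; beyond the scatter) step away from compound 1 itself, and compound 1 is the lowest number of the set, with a 50-fold higher number from compound 1 to compound 3 (1.69 log units; beyond the scatter) separating it from compound 3.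

Compound 4 `COc1ccc(O)c(/C=N/c2ccc(OCc3ccccc3)cc2)c1` is not yet measured. It differs from compound 3 by methoxy in place of nitro on an aromatic carbon. Among the measured compounds shown here, the step that bears on it most is the one from compound 1 to compound 3, where hydroxy gave way to nitro at this same aromatic carbon and the number rose by a 50-fold higher number from compound 1 to compound 3 (1.69 log units; beyond the scatter). Methoxy is closer in make-up to the hydroxy of compound 1 than to the nitro of compound 3, so the change is expected to reverse much of that step. The expected step for compound 4 is a 24-fold lower number from compound 3 to compound 4 (1.39 log units; beyond the scatter) in this assay. Compound 4 is therefore estimated at 2500 nM, with a range of 800 nM to 8000 nM.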

Compound 4, half-maximal inhibitory concentration: 10700 nM
Compound 4: middle estimate off by 4.3-fold (0.63 log units), on the low side, outside the stated range (above it).
By their numbers in this assay, from the lowest: compound 1; then compounds 2 and 4 (each within the scatter of the next); then compound 3.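

In this assay, methoxy in place of nitro on this carbon, para to a hydroxy group, gives a 5.7-fold lower number from compound 3 to compound 4 (0.76 log units; beyond the scatter) and so recovers only part of the ground, while methyl in place of hydrogen on the oxygen still gives an 8.7-fold higher number from compound 1 to compound 4 (0.94 log units; beyond the scatter) in the other direction. At this carbon the three groups therefore fall in a clear order, with hydroxy lowest, methoxy next and nitro highest, and every gap lies beyond the scatter. The added methyl alone separates compound 4 from compound 1, so an oxygen at this carbon does not by itself match the free hydroxy, and no measurement here accounts for this order.

Still open, going by these compounds, is where an amine, a carboxylic acid or a chloro group would fall in this order at the same carbon. Also open, on these data alone, is whether a longer chain on the oxygen, such as ethoxy, would move the number further from that of compound 1 than methoxy does.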